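The source may hold more compounds than are shown below. What is called first, only, known or untested is meant among the compounds shown, and "the series" means these compounds.

Compound 1 `CNC(=O)c1cc(C(=O)NC2CC2)cn(Cc2ccc(C)cc2)c1=O` gives 3.5 in a physicochemical assay for lipophilicity, at pH 7.4; on this read-out lower numbers stand for lower lipophilicity and higher numbers for higher lipophilicity.
Compound 2 `CNC(=O)c1cc(C(=O)NC2CC2)c(C)n(Cc2ccccc2)c1=O` gives 2.9 in this assay.
Compound 3 `CNC(=O)c1cc(C(=O)NC(C)C)cn(Cc2ccccc2)c1=O` gives 3.6 in this assay.

Of the compounds shown here, three sharing one core have been measured in this assay. Compound 1 stands in the upper part of this small set: its value and that of compound 3 lie within the usual scatter of each other, so no order between the two can be read, whereas compound 2 sits clearly lower, beyond the scatter. Going by the values given here, no pair of these measured compounds differs in a single place, so no step between them can be isolated.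

Compound 4 `CNC(=O)c1cc(C(=O)NC2CC2)cn(Cc2cccc3cc[nH]c23)c1=O` has not yet been measured in this assay. It differs from compound 1 in one place: 1H-indol-7-yl in place of 4-methylphenyl on a saturated chain carbon bound to an aromatic nitrogen. Among the compounds with values here, the group that enters carries one hydrogen-bond donor where the group that leaves carried none, and no measured pair offers a direct precedent for this exchange. On that basis a downward step beyond the scatter is expected for a number 0.50 log units lower from compound 1 to compound 4 (beyond the scatter). For compound 4 the estimated value in this assay is 3, expected to fall between 2.6 and 3.4.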

Compound 4, distribution coefficient: 3.7
For compound 4 the middle estimate is 0.70 log units below the measured one, and the stated range ends below it.
By their numbers in this assay, from the lowest: compound 2; then compounds 1, 3 and 4 (each within the scatter of the next).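

Replacing 4-methylphenyl with 1H-indol-7-yl on a saturated chain carbon bound to an aromatic nitrogen gives, in this assay, a number 0.20 log units higher from compound 1 to compound 4 (within the scatter). Going by these compounds alone, this is the first single-place step in the set, and it shows that at this place a group carrying one hydrogen-bond donor can take the place of one carrying none without a difference that can be told from the scatter. No measurement at hand bears on why the two compounds read alike here.

Going by these compounds, it remains open whether a phenyl group bearing a carboxylic acid or an amine at this place would also stay within the scatter. Also open, on these data alone, is whether 1H-indol-7-yl would give a similar step on the core of compound 2, which carries the extra methyl group.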